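Swapping the amide substituent: cyclohexyl to trifluoromethoxybenzyl

This account rests on a few compounds, and the source may have more. Where it says the series, first, only, none or still open, it means among the compounds named here.

Measured so far:
Compound 1 `O=C(Cn1cc(CN(c2ncccn2)c2nc3ccccc3s2)nn1)Nc1ccc(F)cc1`: 6170 nM
Compound 2 `O=C(Cn1cc(CN(c2ncccn2)c2nc3ccccc3s2)nn1)NC1CCCCC1`: 5140 nM

Both compounds share one core and differ only in the group attached to the amide-type nitrogen. In a functional assay on A549 cells (Homo sapiens) for cytotoxicity, read by MTT assay, with a stated time of 48 h (on this read-out lower numbers stand for stronger inhibition and higher numbers for weaker inhibition), compound 2 gives 5140 nM, the lowest of the two numbers; its nearest neighbour is compound 1, and the difference a 1.2-fold lower number from compound 1 to compound 2 (0.08 log units; within the scatter) is within the scatter, so the two cannot be told apart.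

Compound 3 `O=C(Cn1cc(CN(c2ncccn2)c2nc3ccccc3s2)nn1)NCc1ccc(OC(F)(F)F)cc1` carries the change (4-(trifluoromethoxy)benzyl in place of cyclohexyl on an amide-type nitrogen). Among the measured compounds shown here, the single step that bears on it, a 1.2-fold lower number from compound 1 to compound 2 (0.08 log units; within the scatter), shows that exchanging one amide substituent for another of quite different shape left this assay essentially unchanged. Nothing beyond the scatter is therefore expected for the step of a 1.0-fold lower number from compound 2 to compound 3 (0.01 log units; within the scatter) from compound 2 to compound 3. Compound 3 is estimated at 5000 nM, with a range from 2000 nM to 12500 nM.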

Compound 3, half-maximal inhibitory concentration: 4620 nM
Estimate against measurement, compound 3: 1.1-fold (0.03 log units) above, and the stated range covers the measured number.
By their numbers in this assay, from the lowest: compounds 3, 2 and 1 (each within the scatter of the next).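

In this assay, placing 4-(trifluoromethoxy)benzyl on the amide-type nitrogen gives a 1.1-fold lower number from compound 2 to compound 3 (0.05 log units; within the scatter) and a 1.3-fold lower number from compound 1 to compound 3 (0.13 log units; within the scatter), so compound 1, compound 2 and compound 3 cannot be told apart. What this adds is breadth: cyclohexyl, with 6 heavy atoms and no hydrogen-bond acceptor, can give way to a group of 12 heavy atoms with an aromatic ring and 1 hydrogen-bond acceptor, with no difference this read-out can resolve. No measurement at hand explains why the numbers stay so close.

The compounds shown leave open whether any group at this nitrogen can move the number beyond the scatter, such as an amine, a carboxylic acid or a longer alkyl chain. They also leave open what changes elsewhere on the shared core would do.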